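Ester variation at the carbonyl carbon of compound 2

The source may report more compounds than this note shows. Statements on the series, on what has been measured and on what is new or still open speak of the compounds shown alone.

Compound 2 `COc1cc(C2Oc3cc([C@H]4Oc5cc(O)cc(O)c5C(=O)[C@@H]4O)ccc3OC2COC(=O)c2cc([N+](=O)[O-])cc([N+](=O)[O-])c2)ccc1O` stands highest of the two numbers in a functional assay, read by spectrophotometry, with a stated time of 30 min (a lower number here means that less compound is needed, a higher number that more compound is needed for the effect), where compound 2 gives 205000 nM; compound 1 `CCOC(=O)CC(=O)OCC1Oc2ccc([C@H]3Oc4cc(O)cc(O)c4C(=O)[C@@H]3O)cc2OC1c1ccc(O)c(OC)c1` gives 101000 nM, and the step is a 2.0-fold higher number from compound 1 to compound 2 (0.31 log units; beyond the scatter). Compound 3 `COc1cc(C2Oc3cc([C@H]4Oc5cc(O)cc(O)c5C(=O)[C@@H]4O)ccc3OC2COC(=O)c2cc(N)cc([N+](=O)[O-])c2)ccc1O` gives only a limit, > 300000 nM. The remaining steps are an at least 1.4-fold higher number from compound 2 to compound 3 (0.16 log units; that floor lies within the scatter) and an at least 2.9-fold higher number from compound 1 to compound 3 (0.47 log units; beyond the scatter), both running into (the limit of > 300000 nM in this assay, at which 1 of the 3 values shown sits). Compound 4 `COc1cc(C2Oc3cc([C@H]4Oc5cc(O)cc(O)c5C(=O)[C@@H]4O)ccc3OC2COC(=O)/C=C/c2ccc(C)cc2)ccc1O` differs from compound 2 in one place: 2-(4-methylphenyl)ethenyl in place of 3,5-dinitrophenyl on a carbonyl carbon. The three measured steps, each at the same carbonyl carbon, stay modest, so for compound 4 a modest step in either direction, or none beyond the scatter, is expected. Compound 4 is therefore estimated at 150000 nM (range 60000 nM to 400000 nM), which corresponds to an expected step of a 1.4-fold lower number from compound 2 to compound 4 (0.14 log units; within the scatter).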

Compound 4, half-maximal effective concentration: 136000 nM
Compound 4: middle estimate off by 1.1-fold (0.04 log units), on the high side; the range from low to high includes it.
By their numbers in this assay, from the lowest: compounds 1, 4 and 2 (each within the scatter of the next, the first and the last beyond it). At a limit, above all of these: compound 3.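

At the carbonyl carbon, 2-(4-methylphenyl)ethenyl, a carbon-only group, stays within the scatter of both 3,5-dinitrophenyl (a 1.5-fold lower number from compound 2 to compound 4 (0.18 log units; within the scatter)) and (ethoxycarbonyl)methyl (a 1.3-fold higher number from compound 1 to compound 4 (0.13 log units; within the scatter)) in this assay, so neither nitro groups nor ester oxygens in this group are needed to hold the number at this level. Compound 3 gives a limit and not a number, so (an at least 2.2-fold lower number from compound 3 to compound 4 (0.34 log units; beyond the scatter)) sets only a floor: the limit of > 300000 nM in this assay, at which 1 of the 4 values shown sits.

Still open, as far as these compounds go, is whether any group here moves the number well beyond the scatter of compound 1. A carboxylic acid, an amine or a longer chain at this carbonyl carbon would test that.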